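This account rests on a few compounds, and the source may have more. Where it says the series, first, only, none or still open, it means among the compounds named here.

Measured in a functional assay on MGC-803 cells (Homo sapiens) for inhibition, read by CCK-8 assay, with a stated time of 48 h; on this read-out lower numbers stand for stronger inhibition and higher numbers for weaker inhibition:
compound 1 `COc1ccc(CN(C(=O)CSC(=S)N2CCN(C(=O)OC(C)(C)C)CC2)c2cc(OC)c(OC)c(OC)c2)cc1F`: 4870 nM
compound 2 `COc1ccc(CN(C(=O)CSC(=S)N2CCN(C(=O)OC(C)(C)C)CC2)c2cc(OC)c(OC)c(OC)c2)cc1Br`: 3710 nM
compound 3 `COc1ccc(CN(C(=O)CSC(=S)N2CCN(C(=O)OC(C)(C)C)CC2)c2cc(OC)c(OC)c(OC)c2)cc1N=[N+]=[N-]`: 810 nM

Compound 3 has the lowest number of the three, and its gaps to both others lie beyond the scatter. Compound 4 `COc1ccc(CN(C(=O)CSC(=S)N2CCN(C(=O)OC(C)(C)C)CC2)c2cc(OC)c(OC)c(OC)c2)cc1N` carries amino in place of azido on an aromatic carbon. Swapping bromo for fluoro made little difference, a 1.3-fold lower number from compound 1 to compound 2 (0.12 log units; within the scatter). Azido made a modest difference, both in place of fluoro, a 6.0-fold lower number from compound 1 to compound 3 (0.78 log units; beyond the scatter), and in place of bromo, a 4.6-fold lower number from compound 2 to compound 3 (0.66 log units; beyond the scatter). Within the data shown here, no amino compound has been measured yet, so this is indirect evidence. Removing azido is expected to give a modest step to a higher number in this assay, though a step within the scatter remains possible. The estimated change is a 2.3-fold higher number from compound 3 to compound 4 (0.37 log units; beyond the scatter). Compound 4 is estimated at 1900 nM, with an expected range of 600 nM to 5000 nM.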

Compound 4, half-maximal inhibitory concentration: 184 nM
Compound 4: the middle estimate sits 10-fold (1.01 log units) above what was measured; measured number below the stated range.
By their numbers in this assay, from the lowest: compound 4; then compound 3; then compounds 2 and 1 (each within the scatter of the next).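

In this assay the place ortho to a methoxy group does not need the three nitrogens of azido: the single nitrogen of amino gives a further gain (a 4.4-fold lower number from compound 3 to compound 4 (0.64 log units; beyond the scatter)). Against the halogens the gain from amino is large, both over bromo (a 20-fold lower number from compound 2 to compound 4 (1.30 log units; beyond the scatter)) and over fluoro (a 26-fold lower number from compound 1 to compound 4 (1.42 log units; beyond the scatter)). No measurement at hand explains this gain. Going by these compounds, whether the amino hydrogens matter remains open, and methylamino, dimethylamino or acetamido at this place would test that. Hydroxyl would show whether nitrogen itself is needed there.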